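This account rests on a few compounds, and the source may have more. Where it says the series, first, only, none or still open, it means among the compounds named here.

Compound 1, `CCCC(=O)OC1CCC(CN2CCN(c3cc(=O)c4cc(C(F)(F)F)cc([N+](=O)[O-])c4s3)CC2)CC1`, in an ADME assay on Vero cells (Chlorocebus sabaeus) for cytotoxicity, read by MTT assay, with a stated time of 48 h (on this read-out lower numbers stand for stronger inhibition and higher numbers for weaker inhibition), gives > 64 ug/mL, which is a limit of the assay rather than a number.
Compound 2, `O=C(OC1CCC(CN2CCN(c3cc(=O)c4cc(C(F)(F)F)cc([N+](=O)[O-])c4s3)CC2)CC1)c1cccc(C(F)(F)F)c1`, in this assay gives > 64 ug/mL, again a limit.
Compound 3, `O=C(OC1CCC(CN2CCN(c3cc(=O)c4cc(C(F)(F)F)cc([N+](=O)[O-])c4s3)CC2)CC1)C1CCC1`, in this assay gives > 64 ug/mL, also a limit.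

Compound 3 therefore stands where every measured compound stands: the limit of > 64 ug/mL in this assay, at which 3 of the 3 values shown sit. None of the three measured steps can be read in size, since each joins two limits: a step that the two limits leave unreadable from compound 1 to compound 2, a step that the two limits leave unreadable from compound 1 to compound 3 and a step that the two limits leave unreadable from compound 2 to compound 3. Compound 4, `O=C(OC1CCC(CN2CCN(c3cc(=O)c4cc(C(F)(F)F)cc([N+](=O)[O-])c4s3)CC2)CC1)C1CCCCC1`, differs from compound 3 by cyclohexyl in place of cyclobutyl on a carbonyl carbon. The three measured steps all change the group on the same carbonyl carbon, and none of them moved a compound away from the limit, so the step in this assay is expected to show nothing beyond the scatter: a number no higher from compound 3 to compound 4 (the limit leaves the size open). Compound 4 is thus estimated to give about 64 ug/mL, with a range from 32 ug/mL to 128 ug/mL, and most probably to come back as a limit once more.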

Compound 4, half-maximal inhibitory concentration: > 64 ug/mL
Compound 4: a limit, no number; the forecaster's own chance of this, stated with the estimate: 85%; the middle value lies on the limit itself.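

Compound 4 also gives a limit in this assay, and its steps from compound 1, compound 2 and compound 3 cannot be read in size: the limit of > 64 ug/mL in this assay, at which 4 of the 4 values shown sit.

No compound shown gives a number, which leaves open whether the group on the carbonyl carbon makes any difference in this assay.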